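Working notes on two measured compounds and one open

The compounds below may be only part of what the source reports. "The series", "measured", "known", "first", "only" and "open" are said of these compounds alone.

Compound 1 `CC(=O)Nc1nn(C)c2cc(-c3ccc(N4CCN(C)CC4)cc3)[nH]c(=O)c12`: 6%
Compound 2 `CC(C)(C)c1cc2nn(-c3ccccc3)c(N)c2c(=O)[nH]1`: -1%

In an assay on isolated protein for inhibition of protein kinase C zeta type (Homo sapiens), read by mobility shift assay, tested at 30 uM (on this read-out lower numbers stand for less inhibition and higher numbers for more inhibition at the one concentration tested (going by the name of the read-out)), compound 1 gives 6%, while compound 2 gives -1%. Compound 2 stands lowest of the two numbers, but its gap to compound 1 lies within the scatter, so neither is set apart. Compound 3 `COc1ccccc1-c1cc2nn(-c3ccccc3)c(N)c2c(=O)[nH]1` differs from compound 2 by 2-methoxyphenyl in place of tert-butyl on an aromatic carbon. For the measured compounds named here, no step between measured compounds is available to size this change. The step of a number 6 percentage points higher from compound 2 to compound 3 (within the scatter) is expected to stay within the scatter, with no direction claimed. Compound 3 is therefore estimated at 5%, ranging from -10% to 25%.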

Compound 3, a percentage reported as inhibition, at one concentration (the size of the read-out at that concentration, not a potency): 4%
For compound 3 the middle estimate is 1 percentage points above the measured one; the measured number falls inside the stated range.
By their numbers in this assay, from the lowest: compounds 2, 3 and 1 (each within the scatter of the next).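

Read in this assay the exchange of tert-butyl for 2-methoxyphenyl gives a number 5 percentage points higher from compound 2 to compound 3 (within the scatter) at this aromatic carbon next to the ring nitrogen. A larger group carrying a six-membered aromatic ring and a hydrogen-bond acceptor therefore does not set compound 3 apart from compound 2 at this position. No measured evidence bears on this result.

Going by these compounds, what a carboxylic acid or a primary amine would give at this carbon stays open. On these data alone, whether any group here can lift the inhibition beyond the scatter also stays open.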